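The source may hold more compounds than are shown below. What is called first, only, known or untested is meant among the compounds shown, and "the series" means these compounds.

Compound 1, `COc1ccc2cc(C(C)c3nnc4n3N=C(c3ccc([N+](=O)[O-])cc3)CS4)ccc2c1`, gives 18800 nM in a functional assay on MCF7 cells (Homo sapiens) for inhibition, read by sulforhodamine B assay, with a stated time of 72 h; a lower number here means a stronger inhibitor, a higher number a weaker inhibitor.
Compound 2, `CC(c1ccc(-c2ccccc2)c(F)c1)c1nnc2n1N=C(c1ccc(OC(F)(F)F)cc1)CS2`, gives 4800 nM in this assay.

Of the two numbers recorded so far in this assay, compound 2 holds the lower one. Its nearest neighbour, compound 1, stands clearly higher, and the gap between them lies beyond the usual scatter of repeated measurements, so compound 2 is the stronger inhibitor of the pair on these numbers.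

Compound 3, `CC(c1ccc(-c2ccccc2)c(F)c1)c1nnc2n1N=C(c1ccc(Cl)cc1Cl)CS2`, has not yet been measured. It differs from compound 2 in a single place: 2,4-dichlorophenyl in place of 4-(trifluoromethoxy)phenyl on a carbon with a double bond to nitrogen. Within the data shown here, no pair of measured compounds differs in only this way, so the size of this change cannot be read from the two compounds in hand. Compound 2 gives 4800 nM, and compound 3 is expected to land near it. Compound 3 is estimated at 4000 nM in this assay, with a range from 1200 nM to 15000 nM. The step this estimate implies, a 1.2-fold lower number from compound 2 to compound 3 (0.08 log units; within the scatter), is expected to stay within the scatter, with no clear direction.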

Compound 3, half-maximal inhibitory concentration: 7600 nM
Compound 3: the middle estimate sits 1.9-fold (0.28 log units) below what was measured; low and high end bracket the measured number.
By their numbers in this assay, from the lowest: compounds 2 and 3 (each within the scatter of the next); then compound 1.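

In this assay, among these compounds, 2,4-dichlorophenyl in place of 4-(trifluoromethoxy)phenyl on a carbon with a double bond to nitrogen gives a 1.6-fold higher number from compound 2 to compound 3 (0.20 log units; within the scatter), the first step that isolates this position. The step stays within the scatter, so this assay does not separate the two groups, even though the exchange removes the oxygen and all three fluorine atoms, adds two chlorine atoms, and leaves a six-membered aromatic ring of carbon only at this place. No independent measurement bears on why the two groups give numbers so close together, and this single pair offers no explanation.

On these data alone, it remains open whether this insensitivity extends beyond these two substituted phenyl groups, for example to an unsubstituted phenyl, a phenyl carrying an amine or a carboxylic acid, or a saturated cyclohexyl ring at the same carbon. It is also unknown whether the same exchange would give a similar step if the rest of the molecule differed from the part shared by compound 2 and compound 3.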